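The source may report more compounds than this note shows. Statements on the series, on what has been measured and on what is new or still open speak of the compounds shown alone.

The measured compounds:
compound 1 `Cc1nc2ccc(-c3ccc(CN4CCC[C@@H]4CO)cc3)cc2n1Cc1ccccc1` with 440 nM
compound 2 `O=S(=O)(Cc1cccc(OCc2ccc(CN3CCC[C@@H]3CO)cc2)c1)C1CC1` with 10 nM

In an assay on cells for inhibition of sphingosine kinase 1 (Homo sapiens), read by fluorescence polarization, with stated times of 15 min and 1 h (a lower number here means a stronger inhibitor, a higher number a weaker inhibitor), compound 2 stands at the lowest of the two numbers; its nearest neighbour is compound 1, whose number is higher by a margin well beyond the usual scatter. Compound 3 `Cc1nc(-c2cccc(OCc3ccc(CN4CCC[C@@H]4CO)cc3)c2)no1` keeps the common portion of compound 2 and alters the other end: 5-methyl-1,2,4-oxadiazol-3-yl in place of (cyclopropylsulfonyl)methyl on an aromatic carbon. No change between two measured compounds of this kind is recorded in this assay, so there is nothing to calibrate it against directly. The expectation is that compound 3 is a weaker inhibitor than compound 2 in this assay, by a step of moderate size rather than within the scatter, though with wide uncertainty. Compound 3 is therefore estimated at 120 nM, with a range from 20 nM to 800 nM. The expected step is a 12-fold higher number from compound 2 to compound 3 (1.08 log units; beyond the scatter).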

Compound 3, half-maximal inhibitory concentration: 4.5 nM
The estimate for compound 3 lay 27-fold (1.43 log units) above the measured number; measured number below the stated range.
By their numbers in this assay, from the lowest: compound 3; then compound 2; then compound 1.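

In this assay the exchange of (cyclopropylsulfonyl)methyl for 5-methyl-1,2,4-oxadiazol-3-yl gives a 2.2-fold lower number from compound 2 to compound 3 (0.35 log units; beyond the scatter), so the sulfone-bearing group is not required at this place, on an aromatic carbon meta to a large group. The place accepts a five-membered aromatic ring with three hetero atoms as well as a group with a three-membered carbon ring, and the number stays low, with compound 3 at 4.5 nM. Nothing available bears on why the number moves in this direction.

Going by these compounds, whether the step belongs to the oxadiazole ring itself or to its methyl remains open, since a single exchange cannot separate the two. On these data alone, how a nitrile, a carboxylic acid or a primary amide would fare at this place is also open.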